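Benzyl in place of hydroxybutyl on the shared core

This account rests on a few compounds, and the source may have more. Where it says the series, first, only, none or still open, it means among the compounds named here.

compound 1 `[SeH]c1nc(NCc2ccccc2)c2cccnc2n1`: 30500 nM
compound 2 `COc1ccc(CNc2nc(SC)nc3ncccc23)cc1`: > 100000 nM
compound 3 `CSc1nc(NCCCCCO)c2cccnc2n1`: > 100000 nM

In a functional assay on CCRF-CEM cells (Homo sapiens) for cytotoxicity, read by MTT assay, with a stated time of 72 h (a higher number here means a weaker inhibitor of growth, a lower number a stronger inhibitor of growth), compound 1 gives 30500 nM. For compound 2 the value > 100000 nM is a limit of the assay, not a number. For compound 3 the value > 100000 nM is likewise a limit, not a number. Compound 3 therefore sits at the limit of > 100000 nM in this assay, at which 2 of the 3 values shown sit, together with compound 2, while compound 1 alone shows a number. Compound 4, `CSc1nc(NCc2ccccc2)c2cccnc2n1`, differs from compound 3 by phenyl in place of 4-hydroxybutyl on a saturated chain carbon bound to a nitrogen on an aromatic ring. Within the data shown here, no measured pair isolates this change. Compound 1 carries the same benzyl group on the amine nitrogen with 30500 nM. Starting from a limit, the step from compound 3 to compound 4 is expected to run toward stronger growth inhibition, an at least 1.6-fold lower number from compound 3 to compound 4 (0.22 log units; that floor lies within the scatter). Compound 4 is estimated at 60000 nM, within 20000 nM to 150000 nM.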

Compound 4, concentration for 50% growth inhibition: 56300 nM
Compound 4: middle estimate off by 1.1-fold (0.03 log units), on the high side; the range from low to high includes it.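

In this assay two changes now read as steps: phenyl in place of 4-hydroxybutyl gives an at least 1.7-fold lower number from compound 3 to compound 4 (0.24 log units; that floor lies within the scatter), and hydrogen in place of methoxy on an aromatic carbon gives an at least 1.7-fold lower number from compound 2 to compound 4 (0.24 log units; that floor lies within the scatter). Each step starts from a limit and so gives only a floor: the limit of > 100000 nM in this assay, at which 2 of the 4 values shown sit.

The group of 1 carbon and 1 sulfur in place of the selenium atom gives a 1.8-fold higher number from compound 1 to compound 4 (0.27 log units; within the scatter), so this change does not separate the two compounds.

Open, going by these compounds, is whether an amine or a carboxylic acid in place of phenyl on that saturated chain carbon would move the number beyond the scatter.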